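This account rests on a few compounds, and the source may have more. Where it says the series, first, only, none or still open, it means among the compounds named here.

Measured in an ADME assay on microsomes from liver (Rattus norvegicus), read by LC-MS, using NADPH, with a stated time of 10 min, tested at 0.5 uM; a higher number here means that more of the compound is left, a lower number that less of the compound is left:
Compound 1 `Cc1nc2cc(-c3cccc(OCc4ccccc4)c3)nn2c(-c2cc(F)c3c(c2C)CCCO3)c1C(OC(C)(C)C)C(=O)O`: 83%
Compound 2 `Cc1nc2cc(-c3cccc(-c4ccccc4)c3)nn2c(-c2cc(F)c3c(c2C)CCCO3)c1C(OC(C)(C)C)C(=O)O`: 100%

Compound 1 holds the lower of these two numbers. Compound 3 `Cc1nc2cc(-c3cccc(OCc4ccccc4)c3)nn2c(N2CCC(C)(C)CC2)c1C(OC(C)(C)C)C(=O)O` has not yet been measured. It keeps the benzyloxy group of compound 1 but differs elsewhere: a group of 8 heavy atoms (7 carbon, 1 nitrogen; one six-membered non-aromatic ring with 1 hetero atom) in place of a group of 12 heavy atoms (10 carbon, 1 oxygen, 1 fluorine; one six-membered non-aromatic ring with 1 hetero atom, one six-membered aromatic ring of carbon only), on an aromatic carbon. The entering group, 4,4-dimethylpiperidin-1-yl, sits on an aromatic carbon of the shared core, ortho to a carboxy(tert-butoxy)methyl group.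

Within the data shown here, the only measured step, a number 17 percentage points higher from compound 1 to compound 2 (beyond the scatter), came with phenyl in place of benzyloxy. It therefore lies on another part of the molecule and says nothing direct about this exchange, though it does give a sense of scale for swapping one group. Among the measured compounds shown here, no measured compound varies the group at the changed place, so the direction is a judgement. Compound 1 at 83% has more room to fall than to rise, so a modest fall is expected. The expected change is a number 11 percentage points lower from compound 1 to compound 3 (beyond the scatter), and this is only an estimate. The estimate for compound 3 is 72%, expected to lie between 45% and 95%.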

Compound 3, percent of the compound remaining: 100%
Compound 3: middle estimate off by 28 percentage points, on the low side; measured number outside the range, above it.
By their numbers in this assay, from the lowest: compound 1; then compounds 2 and 3 (each within the scatter of the next).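

In this assay, the place on the shared core next to the ring nitrogen, ortho to the carboxy(tert-butoxy)methyl group, also affects the result: a number 17 percentage points higher from compound 1 to compound 3 (beyond the scatter) when 4,4-dimethylpiperidin-1-yl takes the place of the two-ring group of 12 heavy atoms. Among these compounds, the only earlier step changed the benzyloxy group, whereas compound 3 keeps it and still gives 100%. No measurement shown here explains the rise.

This exchange alters several features at once, including the aromatic ring, the fluorine and the nitrogen attachment, and the compounds shown do not separate these features; a plain piperidin-1-yl group without the two methyl groups, or a morpholin-4-yl group, at the same place would begin to do so. With compound 3 at 100%, this read-out also has no room to show any further gain, leaving open whether the new group would still stand out over a longer incubation or at a higher concentration.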